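The compounds below may be only part of what the source reports. "The series", "measured", "known", "first", "only" and "open" are said of these compounds alone.

Compound 1 `CCN(CC)CCCNC(=O)c1ccc(C(CC)(CC)c2ccc(C#CC(O)(CC)CC)c(C)c2)n1CC` gives, in an assay on cells for agonist activity at vitamin D3 receptor (Homo sapiens), read by microscopy (on this read-out lower numbers stand for an effect already at smaller amounts and higher numbers for an effect only at larger amounts of compound), 68.9 nM. Compound 2 `C#CCCOC(=O)c1ccc(C(CC)(CC)c2ccc(C#CC(O)(CC)CC)c(C)c2)n1CC` differs from it by (but-3-yn-1-yl)oxy in place of (3-(diethylamino)propyl)amino on a carbonyl carbon. In this assay compound 2 gives > 50 nM, which is a limit of the assay and not a number. The step that the limit leaves unreadable from compound 1 to compound 2 therefore has no readable size because of the limit of > 50 nM in this assay, at which 1 of the 2 values shown sits. Compound 3 `CCn1c(C(=O)On2nnc3ccccc32)ccc1C(CC)(CC)c1ccc(C#CC(O)(CC)CC)c(C)c1` carries a group of 9 heavy atoms (6 carbon, 3 nitrogen; one five-membered aromatic ring with 3 hetero atoms, one six-membered aromatic ring of carbon only) in place of a group of 4 heavy atoms (4 carbon; no ring), on an oxygen next to a carbonyl group. No measured step bears directly on this change, since the only step shown is itself unreadable, and the only number shown is that of compound 1, 68.9 nM. Compound 3 is accordingly expected at 100 nM, with a range from 30 nM to 400 nM, and it may again come back as a limit. The expected step that the limit leaves unreadable from compound 2 to compound 3 can only be set against the limit that compound 2 shows.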

Compound 3, half-maximal effective concentration: > 50 nM
Compound 3 gave a limit, no number (the forecaster's own chance of this, stated with the estimate: 50%); the middle value does not contradict the limit.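

In this assay compound 3 gives > 50 nM, which is a limit and not a number. The steps from compound 1 and from compound 2 to compound 3 cannot be read, because of one thing: the limit of > 50 nM in this assay, at which 2 of the 3 values shown sit. The compounds shown leave open where compound 2 and compound 3 actually stand relative to compound 1.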